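Removing One Chloro Group from a Fused Core

The source may report more compounds than this note shows. Statements on the series, on what has been measured and on what is new or still open speak of the compounds shown alone.

Measured compounds:
Compound 1, `ClCc1ccc(Cn2cnc3c(Cl)ncnc32)cc1`, gives 1280 nM
Compound 2, `ClCc1ccccc1Cn1cnc2c(Cl)nc(Cl)nc21`, gives 1380 nM

Both numbers come from a functional assay on M14 cells (Homo sapiens) for cytotoxicity, read by sulforhodamine B assay, with a stated time of 48 h; on this read-out higher numbers stand for weaker inhibition of growth and lower numbers for stronger inhibition of growth. In this assay compound 2 gives 1380 nM, and compound 1 gives 1280 nM; these two numbers lie within the usual scatter of each other, so no difference between the two compounds can be claimed from them.

Compound 3, `ClCc1ccccc1Cn1cnc2c(Cl)ncnc21`, is the unmeasured compound. It differs from compound 2 in one place: hydrogen in place of chloro on an aromatic carbon. Going by the values given here, no measured pair shows the effect of this particular change, so the expected step in this assay cannot rest on a measured step. Compound 1 also carries a single chloro group on its core and gives 1280 nM, which suggests that a single chloro group is compatible with a number near that of compound 2. The step from compound 2 to compound 3 is therefore expected to be a 1.0-fold higher number from compound 2 to compound 3 (0.01 log units; within the scatter), not beyond the scatter. For compound 3 the estimate is 1400 nM, with a range from 500 nM to 4000 nM.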

Compound 3, concentration for 50% growth inhibition: 1950 nM
Estimate against measurement, compound 3: 1.4-fold (0.14 log units) below; the measured number falls inside the stated range.
By their numbers in this assay, from the lowest: compounds 1, 2 and 3 (each within the scatter of the next).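

Going by these compounds alone, this pair gives the first direct reading of hydrogen in place of chloro on the aromatic carbon between two ring nitrogen atoms. In this assay the swap gives a 1.4-fold higher number from compound 2 to compound 3 (0.15 log units; within the scatter), so the chloro group at this position is not needed for compound 3 to inhibit growth in these cells. Nothing measured here bears on why the swap leaves the number within the scatter.

At this position the compounds shown carry only chloro or hydrogen, so the effect of an amine, a methoxy group or a longer chain there remains open. Compound 1 also carries hydrogen at this position, but its partner with chloro there is not among the compounds shown, so whether the swap reads the same in that compound is open too.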